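Swapping Methoxy for Methyl on a Shared Core

The source may report more compounds than this note shows. Statements on the series, on what has been measured and on what is new or still open speak of the compounds shown alone.

Three close relatives of one core have been measured in a functional assay on HeLa cells (Homo sapiens) for antiproliferative activity, with a stated time of 5 days; a higher number here means a weaker inhibitor, a lower number a stronger inhibitor. Compound 1 has the structure `COc1ccc(-n2nc(-c3ccc4ccccc4c3)nc2N2C(=O)COC23C=CC(=O)C=C3)cc1`, and in this assay compound 1 gives 200 nM. Compound 2, `Cc1ccc(-n2nc(-c3ccc4ccccc4c3)nc2N2C(=O)COC23C=CC(=O)C=C3)cc1`, carries methyl in place of methoxy on an aromatic carbon; in this assay compound 2 gives 150 nM, and the step is a 1.3-fold lower number from compound 1 to compound 2 (0.12 log units; within the scatter). Compound 3, `COc1ccc(-n2nc(-c3ccc4ccccc4c3)nc2N2C(=O)C(C)OC23C=CC(=O)C=C3)cc1`, is altered at a different place; in this assay compound 3 gives 140 nM, and the step is a 1.4-fold lower number from compound 1 to compound 3 (0.15 log units; within the scatter). Both steps are small enough to be ordinary repeat-to-repeat variation, so none of the three can be called stronger or weaker than another.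

Compound 4, `Cc1ccc(-n2nc(-c3ccc4ccccc4c3)nc2N2C(=O)C(C)OC23C=CC(=O)C=C3)cc1`, has not yet been measured. It differs from compound 3 by methyl in place of methoxy on an aromatic carbon. For the measured compounds named here, this is the same change that turns compound 1 into compound 2, with the surroundings of the altered carbon described in the same words in both cases; the only distinction is that compound 3 and compound 4 sit on a core that differs from that of compound 1 and compound 2 by methyl in place of hydrogen on a saturated ring carbon. Because the same change once gave a 1.3-fold lower number from compound 1 to compound 2 (0.12 log units; within the scatter), the step from compound 3 to compound 4 is expected to be a 1.3-fold lower number from compound 3 to compound 4 (0.10 log units; within the scatter), a shift that would again fall inside normal measurement noise. Compound 4 is therefore estimated at 110 nM, with a likely range from 60 nM to 200 nM.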

Compound 4, half-maximal inhibitory concentration: 530 nM
Estimate against measurement, compound 4: 4.8-fold (0.68 log units) below, outside the stated range (above it).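

In this assay, the two changes behave differently once they are combined: methyl in place of methoxy gives a 3.8-fold higher number from compound 3 to compound 4 (0.58 log units; beyond the scatter), and methyl in place of hydrogen on the saturated ring carbon gives a 3.5-fold higher number from compound 2 to compound 4 (0.55 log units; beyond the scatter), although each change made no clear difference when it was first made on compound 1. The swap from 4-methoxyphenyl to 4-methylphenyl therefore did not carry over from one core to the other, and a step measured on one core was a poor guide to the same step on its neighbour: the same change on two cores in this assay, a 1.3-fold lower number (0.12 log units; within the scatter) from compound 1 to compound 2 and a 3.8-fold higher number (0.58 log units; beyond the scatter) from compound 3 to compound 4, 5.0-fold (0.70 log units) apart, beyond the scatter of two such steps. These four compounds show that the two changes do not simply add up here, but they do not show why, nor how the swap would behave on any other core, and the same holds when the comparison is read through the added ring methyl: the same change on two cores in this assay, a 1.4-fold lower number (0.15 log units; within the scatter) from compound 1 to compound 3 and a 3.5-fold higher number (0.55 log units; beyond the scatter) from compound 2 to compound 4, 5.0-fold (0.70 log units) apart, beyond the scatter of two such steps.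

As far as these compounds go, it remains open whether this dependence is particular to methyl, or whether a chlorine atom or an amine in place of the methoxy would also respond to the added ring methyl. An ethyl group on the saturated ring carbon would test whether the second core's behaviour extends beyond a single methyl.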